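A few compounds are considered here, and "the series" means these few. Any claim that something is new, unique, unknown or untested is made for them only; others in the source may bear on it.

Compound 1 `C=C(Br)C(=O)Nc1cccc(-c2cn3nc(-c4ccc(F)cc4)sc3n2)c1` carries the shared core with a bromoacrylamide on one phenyl and a 4-fluorophenyl on the other side. Among the measured compounds shown here, in a functional assay on HeLa cells (Homo sapiens) for inhibition, read by cell counting, with a stated time of 4 days (on this read-out higher numbers stand for weaker inhibition and lower numbers for stronger inhibition), compound 1 gives 870 nM, the lowest of the three numbers measured so far. For the measured compounds named here, compound 2 `CCOc1ccc(-c2nn3cc(-c4cccc(N)c4)nc3s2)cc1` gives 94000 nM in this assay, and compound 3 `Nc1cccc(-c2cn3nc(CCc4ccccc4)sc3n2)c1` gives 242000 nM; both gaps to compound 1 lie beyond the scatter, but each of these two compounds differs from compound 1 in more than one place, so their values show only that compound 1 sits far lower, not what any single change does.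

Compound 4 `C=C(Br)C(=O)Nc1cccc(-c2cn3nc(-c4ccc(C)cc4)sc3n2)c1` differs from compound 1 in one place: methyl in place of fluoro on an aromatic carbon, on an aromatic carbon of a six-membered aromatic ring of carbon only, para to a large group. Going by the values given here, no measured pair isolates this swap. Among the compounds with values here, with no comparable step to draw on, the expectation for compound 4 is a step from compound 1 of a 1.0-fold higher number from compound 1 to compound 4 (0.01 log units; within the scatter), that is, none beyond the scatter. For compound 4 the estimate in this assay is 900 nM, with a range from 350 nM to 2500 nM.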

Compound 4, half-maximal inhibitory concentration: 2000 nM
For compound 4 the middle estimate is 2.2-fold (0.35 log units) below the measured one; the range from low to high includes it.
By their numbers in this assay, from the lowest: compound 1; then compound 4; then compound 2; then compound 3.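

Among the compounds shown here, the pair compound 1 and compound 4 is the first single-place comparison: in this assay, going from 4-fluorophenyl to 4-methylphenyl gives a 2.3-fold higher number from compound 1 to compound 4 (0.36 log units; beyond the scatter) as a modest step. This position therefore responds to the exchange of fluoro for methyl, even though the swap replaces one heavy atom with one heavy atom and the bromoacrylamide and the shared core stay the same. Nothing at hand accounts for the direction or size of this step.

For the compounds shown here, with only two groups read at this position, it remains open whether hydrogen, chloro, methoxy or an amine would fall nearer to fluoro or to methyl. From the compounds shown here alone, it is also open whether the same swap would give a similar step with a plain acrylamide in place of the bromoacrylamide.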